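The source may hold more compounds than are shown below. What is called first, only, known or untested is meant among the compounds shown, and "the series" means these compounds.

Among the compounds with values here, compound 2 `CCOC(=O)CN1CCC(CCCn2c(COc3ccc(Cl)cc3)nc3c(C)cccc32)CC1` gives 427 nM in an assay on AV12 cells for binding affinity to Neuropeptide Y receptor type 1 (Homo sapiens) (a higher number here means a weaker inhibitor, a lower number a stronger inhibitor), the highest of the two numbers known so far; its nearest neighbour, compound 1 `CCCN1CCC(CCCn2c(COc3ccc(Cl)cc3)nc3c(C)cccc32)CC1`, gives 29 nM. Compound 3 `Cc1cccc2c1nc(COc1ccc(Cl)cc1)n2CCCC1CCN(C(=O)CCN2CCCCC2)CC1` has not been measured yet; it differs from compound 2 by (2-(piperidin-1-yl)ethyl)carbonyl in place of (ethoxycarbonyl)methyl on an amine nitrogen in a ring. Within the data shown here, the only step known at this ring nitrogen, a 15-fold higher number from compound 1 to compound 2 (1.17 log units; beyond the scatter), was large, so a change there can move the number, but no measured step covers the entering group itself. A step of modest size is therefore expected, a 1.4-fold lower number from compound 2 to compound 3 (0.15 log units; within the scatter). For compound 3 the estimate in this assay is 300 nM, within 70 nM to 1300 nM.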

Compound 3, inhibition constant: 260 nM
Estimate against measurement, compound 3: 1.2-fold (0.06 log units) above; low and high end bracket the measured number.
By their numbers in this assay, from the lowest: compound 1; then compounds 3 and 2 (each within the scatter of the next).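

In this assay, placing (2-(piperidin-1-yl)ethyl)carbonyl on the amine nitrogen in a ring instead of (ethoxycarbonyl)methyl gives a 1.6-fold lower number from compound 2 to compound 3 (0.22 log units; within the scatter) and so leaves the two groups indistinguishable, even though the entering group brings a whole six-membered ring. Propyl remains clearly better at this nitrogen, as the change from propyl to this group gives a 9.0-fold higher number from compound 1 to compound 3 (0.95 log units; beyond the scatter) in this assay and thus a large gap persists. From the compounds shown here alone, whether a simple butyl group or a hydroxyethyl group would match propyl stays open. No available evidence explains why these groups differ.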